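The source may hold more compounds than are shown below. What is called first, only, known or untested is meant among the compounds shown, and "the series" means these compounds.

Measured in a physicochemical assay for solubility, in phosphate buffer, at pH 7.4; a higher number here means a more soluble compound, a lower number a less soluble compound:
compound 1 `CC(=O)N1CCC(c2cc3c(-c4ccc(=O)n(C(C)C)c4)ccnc3[nH]2)CC1`: 27000 nM
compound 2 `COc1cc(F)ccc1-c1ccnc2[nH]c(C3CCN(CC(=O)N(C)C)CC3)cc12`: 38000 nM
compound 3 `CN(C)C(=O)CN1CCC(c2cc3c(-c4ccc(=O)n(CCC5CCOCC5)c4)ccnc3[nH]2)CC1`: 370000 nM

Compound 3 stands highest of the three in this assay; compound 2 and compound 1 both lie below it, beyond the scatter. Among the measured compounds shown here, no pair of measured compounds differs in a single place, so no measured step is available.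

Compound 4 `CC(C)n1cc(-c2ccnc3[nH]c(C4CCN(CC(=O)N(C)C)CC4)cc23)ccc1=O` is the next compound. It differs from compound 3 by isopropyl in place of 2-(oxan-4-yl)ethyl on an aromatic nitrogen. For the measured compounds named here, no measured step covers this change. A downward step in this assay is expected, likely beyond the scatter, though not as far down as the values of compound 1 at 27000 nM or compound 2 at 38000 nM. The step expected is a 3.7-fold lower number from compound 3 to compound 4 (0.57 log units; beyond the scatter). For compound 4 the estimate is 100000 nM, within 30000 nM to 300000 nM.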

Compound 4, solubility: 110000 nM
Compound 4: middle estimate off by 1.1-fold (0.04 log units), on the low side; low and high end bracket the measured number.
By their numbers in this assay, from the lowest: compounds 1 and 2 (each within the scatter of the next); then compound 4; then compound 3.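

The substituent on the aromatic nitrogen does move the number in this assay: isopropyl in place of 2-(oxan-4-yl)ethyl gives a 3.4-fold lower number from compound 3 to compound 4 (0.53 log units; beyond the scatter) as a modest step. On the amine nitrogen in a ring, (dimethylcarbamoyl)methyl in place of acetyl gives a 4.1-fold higher number from compound 1 to compound 4 (0.61 log units; beyond the scatter) as a step of similar reach. On the aromatic carbon, the group of 10 heavy atoms in place of the group of 9 heavy atoms gives a 2.9-fold higher number from compound 2 to compound 4 (0.46 log units; beyond the scatter) in the same direction.

Nothing measured here gives a reason for any of these steps. As far as these compounds go, how a longer alkyl chain or a primary amine on that aromatic nitrogen would read in this assay remains open.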